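The compounds below may be only part of what the source reports. "The series", "measured", "known", "first", "only" and "open" are said of these compounds alone.

Working notes on the series. In an in vitro ADME assay on microsomes from liver (Homo sapiens) for metabolic stability, read by HPLC (on this read-out lower numbers stand for slow clearance and higher numbers for fast clearance), compound 3 `NC(=O)[C@@H](CCC(F)(F)F)N(C[C@@H]1CCCCO1)S(=O)(=O)c1ccc(Cl)cc1` gives only a limit, > 300 mL/min/kg. Compound 1 `CC1(C)CO[C@@H]1CN([C@H](CCC(F)(F)F)C(N)=O)S(=O)(=O)c1ccc(Cl)cc1` also gives only a limit, > 293 mL/min/kg. Going by the values given here, compound 2 `NC(=O)[C@@H](CCC(F)(F)F)N(CC1CCCC1)S(=O)(=O)c1ccc(Cl)cc1` is the one compound with a number, 229 mL/min/kg, so compound 3 has no exact place on the scale.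

Compound 4 `NC(=O)[C@@H](CCC(F)(F)F)N(C[C@H]1CCCOC1)S(=O)(=O)c1ccc(Cl)cc1` has the same atoms as compound 3, joined differently: oxan-3-yl in place of oxan-2-yl on a saturated chain carbon bound to a sulfonamide nitrogen. In words, this is oxan-3-yl in place of oxan-2-yl on a saturated chain carbon bound to a sulfonamide nitrogen.

Three measured steps change the same place: an at least 1.2-fold lower number from compound 1 to compound 2 (0.10 log units; that floor lies within the scatter), an at least 1.3-fold higher number from compound 2 to compound 3 (0.11 log units; that floor lies within the scatter) and a step that the two limits leave unreadable from compound 1 to compound 3. The two readable floors lie within the scatter, the third step has no readable size, and none is the same change as this one. On that basis, no step beyond the scatter is expected in this assay, and no direction is favoured.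

The estimated step is an at least 1.2-fold lower number from compound 3 to compound 4 (0.07 log units; that floor lies within the scatter). For compound 4 the estimated clearance is 250 mL/min/kg, with an expected range of 130 mL/min/kg to 400 mL/min/kg.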

Compound 4, clearance: 156 mL/min/kg
Beside the measured number, compound 4's estimate is 1.6-fold (0.20 log units) above it; the measured number falls inside the stated range.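

In this assay compound 4 is the only compound shown with an oxygen-bearing ring on a saturated chain carbon bound to a sulfonamide nitrogen that gives a number and not a limit, with an at least 1.9-fold lower number from compound 3 to compound 4 (0.28 log units; that floor lies within the scatter) and an at least 1.8-fold lower number from compound 1 to compound 4 (0.27 log units; that floor lies within the scatter). Against cyclopentyl there is a 1.5-fold lower number from compound 2 to compound 4 (0.17 log units; within the scatter), so oxan-3-yl and cyclopentyl cannot be told apart in this assay. The change from oxan-2-yl to oxan-3-yl can be read only as a floor, as compound 3 stands at a limit: the limit of > 300 mL/min/kg in this assay, at which 1 of the 4 values shown sits.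

As far as these compounds go, compound 1 also stands at a limit, so its true distance from the other compounds stays open: the limit of > 293 mL/min/kg in this assay, at which 1 of the 4 values shown sits. Also open is whether oxan-4-yl, or a piperidine ring carrying an amine in place of the ring oxygen, would give a step beyond the scatter.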